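The source may report more compounds than this note shows. Statements on the series, on what has been measured and on what is new or still open speak of the compounds shown alone.

Compound 2 `N#CC1=C(N)Oc2c(c3nc4ccccc4nc3c3ccccc23)C12C(=O)N(Cc1cnnn1-c1ccccc1Cl)c1ccccc12` is one of two close analogues tested in an ADME assay on L02 cells (Homo sapiens) for antiproliferative activity, read by MTT assay, with a stated time of 48 h; on this read-out lower numbers stand for stronger inhibition and higher numbers for weaker inhibition. In this assay compound 2 reaches only the limit of the assay, > 50000 nM, so no number is known for it. Compound 1 `N#CC1=C(N)Oc2c(c3nc4ccccc4nc3c3ccccc23)C12C(=O)N(Cc1cnnn1-c1ccc(Cl)cc1)c1ccccc12` also sits at a limit; in this assay compound 1 gives > 50000 nM. Within the data shown here, the single measured step, a step that the two limits leave unreadable from compound 1 to compound 2, therefore cannot be read, since (the limit of > 50000 nM in this assay, at which 2 of the 2 values shown sit). Compound 3 `N#CC1=C(N)Oc2c(c3nc4ccccc4nc3c3ccccc23)C12C(=O)N(Cc1cnnn1-c1cccc(Cl)c1)c1ccccc12` is the third member of the set, and its change from compound 2 is 3-chlorophenyl in place of 2-chlorophenyl on an aromatic nitrogen. No measured value shows whether exchanging 2-chlorophenyl for 3-chlorophenyl moves the read-out at all. Both known values for this series are limits. Compound 3 is therefore expected to remain at that limit, which means a step that the limit leaves unreadable from compound 2 to compound 3. Compound 3 is estimated at 80000 nM, with a range from 30000 nM to 300000 nM.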

Compound 3, half-maximal inhibitory concentration: 35200 nM
Compound 3: the middle estimate sits 2.3-fold (0.36 log units) above what was measured; the range from low to high includes it.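

Among these compounds, compound 3 gives the first real number of the series in this assay, so a chlorophenyl group at this position can yield a measurable value and not only a limit. The 3-chlorophenyl group gives an at least 1.4-fold lower number from compound 2 to compound 3 (0.15 log units; that floor lies within the scatter) and an at least 1.4-fold lower number from compound 1 to compound 3 (0.15 log units; that floor lies within the scatter) as well; both figures are floors within the usual scatter, so they do not yet establish a true difference among the three chlorophenyl groups. The full size of either step cannot be read, because compound 1 and compound 2 each stand at a limit: the limit of > 50000 nM in this assay, at which 2 of the 3 values shown sit.

From the compounds shown here alone, whether the chlorine itself matters remains open, since a plain phenyl, 3-methoxyphenyl or 3-aminophenyl group could read differently in this assay or the same. The compounds shown also leave open whether a carboxylic acid on this ring would move the number at all.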